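The compounds below may be only part of what the source reports. "The series", "measured", "known", "first", "only" and "open" are said of these compounds alone.

Compound 1 `CCOC(=O)CCCCCOc1cccc(CN(C(=O)c2ccc(-c3ccc(C(C)=O)s3)cc2)C(C)C)c1`: > 26000 nM
Compound 2 `CCOC(=O)CCCCCOc1cccc(CN(C(=O)c2ccc(-c3cccc(OC)c3)cc2)C(C)C)c1`: > 21000 nM
Compound 3 `CCOC(=O)CCCCCOc1cccc(CN(C(=O)c2ccc(-c3cccc(C(F)(F)F)c3)cc2)C(C)C)c1`: > 26000 nM

All three compounds were tested in an ADME assay on HepG2 cells (Homo sapiens) for cytotoxicity, read by CellTiter-Glo and resazurin assay, with a stated time of 72 h (on this read-out higher numbers stand for an effect only at larger amounts of compound and lower numbers for an effect already at smaller amounts), and each result is a limit rather than a number. Compound 3 stands at the limit of > 26000 nM in this assay, at which 2 of the 3 values shown sit. The other limit in the series is the limit of > 21000 nM in this assay, at which 1 of the 3 values shown sits.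

Compound 4 `CCOC(=O)CCCCCOc1cccc(CN(C(=O)c2ccc(-c3cccc(Br)c3)cc2)C(C)C)c1` carries bromo in place of trifluoromethyl on an aromatic carbon, meta to a large group: bromo in place of trifluoromethyl on an aromatic carbon.

The closest measured change at this place is a step that the two limits leave unreadable from compound 2 to compound 3, with trifluoromethyl in place of methoxy. Two wider changes of the same substituent give a step that the two limits leave unreadable from compound 1 to compound 2 and a step that the two limits leave unreadable from compound 1 to compound 3. None of these steps has a readable size, so they offer no measured effect to carry over, and no shift in either direction is expected beyond the usual scatter.

The expectation rests on compound 3, whose limit is > 26000 nM. The expected step is an at least 1.0-fold lower number from compound 3 to compound 4 (0.01 log units; that floor lies within the scatter). For compound 4 the estimate is 25000 nM, with an expected range from 12000 nM to 50000 nM, and the result may well be reported only as a limit.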

Compound 4, half-maximal effective concentration: > 26000 nM
Compound 4: a limit, no number; the forecaster's own chance of this, stated with the estimate: 85%; middle value at least 1.0-fold (0.01 log units) away from the limit.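

Within the data shown here, compound 4 is reported only as a limit in this assay, as are compound 1, compound 2 and compound 3, and no step between compound 4 and any of them can be read. The compounds shown leave open whether these four differ at all in this assay.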